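The source may hold more compounds than are shown below. What is called first, only, known or untested is meant among the compounds shown, and "the series" means these compounds.

Three close relatives share one core and differ only in the aryl group on a double-bonded chain carbon bound to a carbonyl carbon and a double-bonded chain carbon. Compound 1 `COc1cccc(/C(=C\c2cn(C(C)=O)c3ccc(OCc4ccccc4)cc23)C(=O)O)c1` carries a 3-methoxyphenyl there, compound 2 `COc1cc(/C(=C\c2cn(C(C)=O)c3ccc(OCc4ccccc4)cc23)C(=O)O)cc(OC)c1OC` a 3,4,5-trimethoxyphenyl, and compound 3 `COc1ccc(/C(=C\c2cn(C(C)=O)c3ccc(OCc4ccccc4)cc23)C(=O)O)cc1OC` a 3,4-dimethoxyphenyl. In a functional assay on A549 cells (Homo sapiens) for cytotoxicity, read by MTT assay, with a stated time of 72 h (on this read-out lower numbers stand for stronger inhibition and higher numbers for weaker inhibition), compound 1 gives 45200 nM, compound 2 gives 89100 nM, and compound 3 gives 54800 nM. Compound 3 stands second highest of these three numbers, yet none of the three is set apart from another beyond the scatter: a 1.2-fold higher number from compound 1 to compound 3 (0.08 log units; within the scatter), a 1.6-fold lower number from compound 2 to compound 3 (0.21 log units; within the scatter) and a 2.0-fold higher number from compound 1 to compound 2 (0.29 log units; within the scatter). Compound 4 `COc1cc(OC)cc(/C(=C\c2cn(C(C)=O)c3ccc(OCc4ccccc4)cc23)C(=O)O)c1` is the unmeasured partner of compound 3, with one rearrangement: 3,5-dimethoxyphenyl in place of 3,4-dimethoxyphenyl on a double-bonded chain carbon bound to a carbonyl carbon and a double-bonded chain carbon. The measured steps that bear on this change are those that add or remove a methoxy on that same ring, and each of them stayed within the scatter, so moving a methoxy from one place on the ring to another is expected to leave the read-out in this assay without a step beyond the scatter. The expected step is a 1.0-fold higher number from compound 3 to compound 4 (0.00 log units; within the scatter). On that basis compound 4 is estimated at 55000 nM, with a range from 25000 nM to 120000 nM.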

Compound 4, half-maximal inhibitory concentration: 26000 nM
Beside the measured number, compound 4's estimate is 2.1-fold (0.33 log units) above it, within the range that was stated.
By their numbers in this assay, from the lowest: compounds 4, 1, 3 and 2 (each within the scatter of the next, the first and the last beyond it).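

Up to this point, every methoxy change on this ring had stayed within the scatter in this assay, and compound 4 now shows that the arrangement of the same two methoxy groups can count on a double-bonded chain carbon bound to a carbonyl carbon and a double-bonded chain carbon, giving a 2.1-fold lower number from compound 3 to compound 4 (0.32 log units; beyond the scatter). Compound 4 also opens a gap to the 3,4,5-trimethoxyphenyl group, with a 3.4-fold lower number from compound 2 to compound 4 (0.53 log units; beyond the scatter), while its step to the 3-methoxyphenyl group stays small, with a 1.7-fold lower number from compound 1 to compound 4 (0.24 log units; within the scatter). So adding a methoxy to this ring has no single fixed size of effect here, and what it does depends on which ring it is added to: the same change on two cores in this assay, a 1.2-fold higher number (0.08 log units; within the scatter) from compound 1 to compound 3 and a 3.4-fold higher number (0.53 log units; beyond the scatter) from compound 4 to compound 2, 2.8-fold (0.45 log units) apart, beyond the scatter of two such steps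

The compounds shown carry only methoxy groups on this ring, so they leave open whether hydroxy or chloro in place of methoxy would show the same dependence on arrangement. They also leave open whether this arrangement would still count with a methyl ester or an amide in place of the carboxylic acid, and they give no reason for the step.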